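Saturating the hydantoin linker: expected effect on stability

The compounds below may be only part of what the source reports. "The series", "measured", "known", "first", "only" and "open" are said of these compounds alone.

Compound 1, `CCC(CC)C(/C=C1\OC(=O)NC1=O)c1ccc(-c2ccc3cccc(F)c3c2)[nH]c1=O`: in an ADME assay on microsomes from liver (Rattus norvegicus) for metabolic stability (a lower number here means that the compound disappears faster, a higher number that the compound lasts longer), compound 1 gives > 3 h, which is a limit of the assay rather than a number.
Compound 2, `Cc1cc(C(/C=C2\OC(=O)NC2=O)C(C)C)c(=O)[nH]c1-c1ccc2cccc(F)c2c1`: in this assay compound 2 gives > 3 h, again a limit of the assay.
Compound 3, `CC(C)C(/C=C1\NC(=O)NC1=O)c1ccc(-c2ccc3cccc(F)c3c2)[nH]c1=O`: in this assay compound 3 gives 1.46 h.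

Compound 3 is therefore the only one of the three with an actual number; the other two sit at the limit of > 3 h in this assay, at which 2 of the 3 values shown sit. Whether compound 3 truly disappears faster than compound 1 or compound 2 cannot be told, since a limit gives no number to compare against.

Compound 4, `CC(C)C(c1ccc(-c2ccc3cccc(F)c3c2)[nH]c1=O)C1NC(=O)NC1=O`, is the next step from compound 3. The change is a group of 7 heavy atoms (3 carbon, 2 nitrogen, 2 oxygen; one five-membered non-aromatic ring with 2 hetero atoms) in place of a group of 8 heavy atoms (4 carbon, 2 nitrogen, 2 oxygen; one five-membered non-aromatic ring with 2 hetero atoms), on a saturated chain carbon bound to an aromatic carbon and a saturated chain carbon. The 2,5-dioxoimidazolidin-4-yl group carries the same two hydrogen-bond donors and two hydrogen-bond acceptors as the group it replaces, so the polar content of the molecule is essentially unchanged.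

Among the measured compounds shown here, no pair of measured compounds differs in only one place, so there is no measured step to guide this one. The step from compound 3 to compound 4 is expected to be small, a 1.2-fold higher number from compound 3 to compound 4 (0.09 log units; within the scatter), not beyond the usual scatter in either direction. Compound 4 is expected to give about 1.8 h in this assay, most likely between 0.8 h and 4 h.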

Compound 4, half-life: 0.145 h
The estimate for compound 4 lay 12-fold (1.09 log units) above the measured number; the whole stated range lies above it.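

In this assay, the change on this saturated chain carbon turns out to be far from neutral, with a 10-fold lower number from compound 3 to compound 4 (1.00 log units; beyond the scatter). The group that enters, 2,5-dioxoimidazolidin-4-yl, has the same ring size, hydrogen-bond donor and acceptor counts and net charge as the group that leaves, yet has one carbon and one double bond outside aromatic rings fewer, so these matching counts did not foretell the size of this first measured one-place step. Nothing measured in these compounds accounts for that size.

Among the compounds shown here, a single step cannot separate the loss of the double bond from the loss of the carbon, and it remains open whether the same change would give a similar step in compounds that carry a longer chain on the shared core, such as the one in compound 1. As far as these compounds go, it is also open what number an amine or a carboxylic acid would give in place of the 2,5-dioxoimidazolidin-4-yl group, on the same saturated chain carbon.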